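The source may hold more compounds than are shown below. What is called first, only, known or untested is meant among the compounds shown, and "the series" means these compounds.

In a functional assay on CNE-2 cells (Homo sapiens) for cytotoxicity, read by sulforhodamine B assay, with a stated time of 48 h (a lower number here means a stronger inhibitor, a higher number a weaker inhibitor), compound 1 `COc1cc(/C=C/C(=O)c2cccc(-c3cccc(F)c3)c2)ccc1O` gives 5690 nM. Sharing the core of compound 1, compound 2 `O=C(/C=C/c1cccc(Br)c1)c1cccc(-c2cccc(F)c2)c1` gives 6550 nM. These two numbers lie within the scatter of each other, so compound 1 stands level with compound 2 and the data do not separate them. Compound 3 `COc1ccc(/C=C/C(=O)c2cccc(-c3cccc(F)c3)c2)cc1OC` has not yet been measured. It differs from compound 1 by a single change, hydroxy to methoxy: methyl in place of hydrogen on an oxygen on an aromatic ring. Among the compounds with values here, no measured pair shows this change directly, so the expectation rests on thin evidence. Compound 2 carries no hydroxy group and still gives 6550 nM, so no step beyond the scatter is expected in this assay, in either direction. The estimated change is small, a 1.1-fold higher number from compound 1 to compound 3 (0.02 log units; within the scatter). For compound 3 the expected value is 6000 nM, with an estimated range of 2500 nM to 14000 nM.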

Compound 3, half-maximal inhibitory concentration: 770 nM
Compound 3: the middle estimate sits 7.8-fold (0.89 log units) above what was measured; measured number below the stated range.
By their numbers in this assay, from the lowest: compound 3; then compounds 1 and 2 (each within the scatter of the next).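

In this assay, replacing hydroxy with methoxy on the aromatic ring gives a 7.4-fold lower number from compound 1 to compound 3 (0.87 log units; beyond the scatter), a step beyond the scatter, so this position responds to the change in a way the earlier pair could not show. The hydrogen on that oxygen is thus not required for the activity seen here: with a methyl in its place, the number falls rather than rises. Nothing shown here accounts for this step.

The compounds shown leave open whether the step belongs to the methyl alone or would also appear with a longer chain on the same oxygen, such as ethoxy, and whether an amine in place of the hydroxy would behave alike. This single pair also leaves open whether the same change would give a similar step on another core.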